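Carbamoyl groups on the aromatic nitrogen of the shared core

The source may hold more compounds than are shown below. What is called first, only, known or untested is meant among the compounds shown, and "the series" means these compounds.

Three compounds have been measured in a functional assay on U-937 cells (Homo sapiens); on this read-out higher numbers stand for weaker inhibition and lower numbers for stronger inhibition:

- compound 1 `COc1cc(C(=O)NS(=O)(=O)c2ccccc2C)ccc1Cc1c[nH]c2ccc(NC(=O)OC3CCCC3)cc12` gives 2 nM
- compound 2 `COc1cc(C(=O)NS(=O)(=O)c2ccccc2C)ccc1Cc1cn(C(=O)N(C)C)c2ccc(NC(=O)OC3CCCC3)cc12` gives 1 nM
- compound 3 `CCN(CC)C(=O)n1cc(Cc2ccc(C(=O)NS(=O)(=O)c3ccccc3C)cc2OC)c2cc(NC(=O)OC3CCCC3)ccc21` gives 0.8 nM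

Compound 3 lies within the scatter of compound 2, and the modest step of a 2.5-fold lower number from compound 1 to compound 3 (0.40 log units; beyond the scatter) sets it clear of compound 1. The next analogue, compound 4 `COc1cc(C(=O)NS(=O)(=O)c2ccccc2C)ccc1Cc1cn(C(=O)NCCCc2ccccc2)c2ccc(NC(=O)OC3CCCC3)cc12`, keeps the shared core and alters one group ((3-phenylpropyl)amino in place of diethylamino on a carbonyl carbon). It has (3-phenylpropyl)amino in place of diethylamino on a carbonyl carbon.

Among the measured compounds shown here, the closest precedent is the exchange of dimethylamino for diethylamino, a 1.3-fold lower number from compound 2 to compound 3 (0.10 log units; within the scatter), which stays within the scatter. Adding a carbamoyl group at all gave only a 2.0-fold lower number from compound 1 to compound 2 (0.30 log units; within the scatter) and a 2.5-fold lower number from compound 1 to compound 3 (0.40 log units; beyond the scatter). For the measured compounds named here, no measured compound carries a ring in this group, so the larger change remains untested.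

In this assay no step beyond the scatter is therefore expected, and the direction is uncertain. The expected step is a 1.9-fold higher number from compound 3 to compound 4 (0.27 log units; within the scatter). For compound 4 the estimated value is 1.5 nM, with an expected range from 0.4 nM to 6 nM.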

Compound 4, half-maximal inhibitory concentration: 0.1 nM
Estimate against measurement, compound 4: 15-fold (1.18 log units) above; the measured number lies below the stated range.
By their numbers in this assay, from the lowest: compound 4; then compounds 3, 2 and 1 (each within the scatter of the next, the first and the last beyond it).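

In this assay the carbonyl carbon on the aromatic nitrogen turns out to accept far more than the two small dialkylamino groups, which stayed within the scatter of each other. Exchanging them for (3-phenylpropyl)amino gives an 8.0-fold lower number from compound 3 to compound 4 (0.90 log units; beyond the scatter) and a 10-fold lower number from compound 2 to compound 4 (1.00 log units; beyond the scatter), and measured against the free aromatic nitrogen the whole (3-phenylpropyl)carbamoyl group gives a 20-fold lower number from compound 1 to compound 4 (1.30 log units; beyond the scatter), so that compound 4 is the most potent of the four, beyond the scatter of each of the others. No evidence is at hand on what lies behind this gain.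

From the compounds shown here alone, the phenyl ring, the chain and the amide hydrogen all enter together in compound 4, so their separate shares remain open. Benzylamino, (3-cyclohexylpropyl)amino or an N-methyl-(3-phenylpropyl)amino group would begin to pull them apart.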